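The source may hold more compounds than are shown below. What is called first, only, known or untested is meant among the compounds shown, and "the series" means these compounds.

Compound 1 `O=C(NNC(=O)c1ccccc1F)c1ccc(NS(=O)(=O)c2cnc(O)nc2O)cc1` and compound 3 `O=C(NNC(=O)c1ccccc1NS(=O)(=O)c1cnc(O)nc1O)c1ccccc1F` carry the same atoms joined differently; the difference between the two cores is not broken down here. In a functional assay on A549 cells (Homo sapiens) for antiproliferative activity, read by MTT assay, with a stated time of 24 h (on this read-out higher numbers stand for weaker inhibition and lower numbers for stronger inhibition), compound 1 gives 7610 nM, and compound 3 gives 7150 nM, the two sitting within the scatter of each other. Compound 2 `O=C(NNC(=O)c1ccc(NS(=O)(=O)c2cnc(O)nc2O)cc1)c1ccc(F)cc1` follows from compound 1 by 4-fluorophenyl in place of 2-fluorophenyl on a carbonyl carbon. In this assay compound 2 reaches only the assay limit, > 20000 nM, which is a limit and not a number. The step of an at least 2.6-fold higher number from compound 1 to compound 2 (0.41 log units; beyond the scatter) therefore rests on the limit of > 20000 nM in this assay, at which 1 of the 3 values shown sits, and can only be read as a lower bound on the loss.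

Compound 4 `O=C(NNC(=O)c1ccccc1NS(=O)(=O)c1cnc(O)nc1O)c1ccc(F)cc1` is the unmeasured partner of compound 3, made by 4-fluorophenyl in place of 2-fluorophenyl on a carbonyl carbon, the same change at the same place as from compound 1 to compound 2. The step of a 3.1-fold higher number from compound 3 to compound 4 (0.49 log units; beyond the scatter) in this assay is expected to resemble the earlier one, since compound 3 starts from 7150 nM, close to compound 1, and the earlier change gave an at least 2.6-fold higher number from compound 1 to compound 2 (0.41 log units; beyond the scatter). Compound 4 is thus estimated at 22000 nM in this assay, expected to lie between 9000 nM and 50000 nM, with a real chance that only a limit is reported.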

Compound 4, half-maximal inhibitory concentration: > 20000 nM
Compound 4: a limit, no number (the forecaster's own chance of this, stated with the estimate: 60%); the middle value is on the limit's open side.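

In this assay compound 4 gives > 20000 nM, which is a limit and not a number. Placing 4-fluorophenyl in place of 2-fluorophenyl on the carbonyl carbon gives an at least 2.7-fold higher number from compound 3 to compound 4 (0.44 log units; beyond the scatter), so a loss beyond the scatter appears on both cores shown, and the direction of the change carries from the core of compound 1 to the core of compound 3: the same change on two cores in this assay, an at least 2.6-fold higher number (0.41 log units; beyond the scatter) from compound 1 to compound 2 and an at least 2.7-fold higher number (0.44 log units; beyond the scatter) from compound 3 to compound 4; the limit leaves it open whether they differ. The size of the loss on either core is not shown, and neither is any match in size, because both 4-fluorophenyl compounds end at the same limit: the limit of > 20000 nM in this assay, at which 2 of the 4 values shown sit.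

From the compounds shown here alone, whether an unsubstituted phenyl or a chlorophenyl on the same carbonyl carbon would hold the values of compound 1 and compound 3 or lose activity remains open. Among these compounds, the pair is seen on only two cores, so how far the change carries to any further core also remains open.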